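From a Chlorophenyl Cyclopropane to a Pyrimidinyl Analogue

The compounds below may be only part of what the source reports. "The series", "measured", "known", "first", "only" and "open" are said of these compounds alone.

Compound 1 `CC(C)(N)CN(C(=O)[C@@H]1C[C@H]1c1ccccc1)c1ccc(-c2ccccc2)cc1` — 1.4 nM
Compound 2 `O=C([C@@H]1C[C@H]1c1ccccc1)N(CC1CCCNC1)c1ccc(-c2ccccc2)cc1` — 10 nM
Compound 3 `CC[C@H](C)[C@H](N)CN(C(=O)[C@@H]1C[C@H]1c1ccccc1Cl)c1ccc(-c2ccccc2)cc1` — > 25000 nM

All three compounds were tested in a functional assay for agonist activity at G protein-coupled receptor 88 (Homo sapiens), read by HTRF and cAMP accumulation; on this read-out higher numbers stand for an effect only at larger amounts of compound and lower numbers for an effect already at smaller amounts. Going by the values given here, compound 1 gives 1.4 nM, and compound 2 gives 10 nM; the step of a 7.1-fold higher number from compound 1 to compound 2 (0.85 log units; beyond the scatter) is the only single-point change among the measured compounds. For compound 3 the assay reports only a limit, > 25000 nM, with no number behind it (the limit of > 25000 nM in this assay, at which 1 of the 3 values shown sits). Among the compounds with values here, compound 3 therefore stands apart from compounds 1 and 2, which both gave measurable values, but it differs from each of them in more than one place, so no single step connects it to them.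

Compound 4 `CC[C@H](C)[C@H](N)CN(C(=O)[C@@H]1C[C@H]1c1cncnc1)c1ccc(-c2ccccc2)cc1` has not yet been measured. It differs from compound 3 by pyrimidin-5-yl in place of 2-chlorophenyl on a saturated ring carbon. Within the data shown here, no measured step concerns this ring on the three-membered ring; the one measured step, a 7.1-fold higher number from compound 1 to compound 2 (0.85 log units; beyond the scatter), sits on the chain at the amide nitrogen and gives no guide here. Because compound 3 sits at the limit (the limit of > 25000 nM in this assay, at which 1 of the 3 values shown sits), the starting point itself is undefined, and compound 4 is expected to remain near that limit, with the estimated step of an at least 1.2-fold lower number from compound 3 to compound 4 (0.09 log units; that floor lies within the scatter). Compound 4 is estimated at 20000 nM, with a range from 1000 nM to 100000 nM, and a further limit report is expected to be likely.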

Compound 4, half-maximal effective concentration: 19000 nM
For compound 4 the middle estimate is 1.1-fold (0.02 log units) above the measured one; low and high end bracket the measured number.
By their numbers in this assay, from the lowest: compound 1; then compound 2; then compound 4. At a limit, above all of these: compound 3.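

In this assay, going by these compounds alone, this is the first measured change on a saturated ring carbon of the three-membered non-aromatic ring: pyrimidin-5-yl in place of 2-chlorophenyl gives an at least 1.3-fold lower number from compound 3 to compound 4 (0.11 log units; that floor lies within the scatter). The position therefore tolerates an exchange of one six-membered aromatic ring for another while still yielding a readable result, as compound 4 gives 19000 nM and not a limit. The true size of the step cannot be read, however, since only its floor is known and the value for compound 3 is a limit: the limit of > 25000 nM in this assay, at which 1 of the 4 values shown sits.

The compounds shown leave open which part of the exchange matters, for the two groups differ both in the chlorine and in the two ring nitrogens, and a pyridin-3-yl or an unsubstituted phenyl on this same chain would begin to separate those parts. They also leave open whether pyrimidin-5-yl gives a similar result when paired with the 1-amino-1-methylethyl group of compound 1 or the piperidin-3-yl group of compound 2.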